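This account rests on a few compounds, and the source may have more. Where it says the series, first, only, none or still open, it means among the compounds named here.

Measured so far:
compound 1 `O=C1NCCc2nc(C#Cc3ccccc3F)sc21` — 1500 nM
compound 2 `CC(=O)N1CCc2nc(C#Cc3ccccc3)sc2C1` — > 10000 nM
compound 3 `O=C(C1CC(F)(F)C1)N1CCc2nc(C#Cc3cccc(F)c3)sc2C1` — 2.5 nM

In an assay on HEK293 cells for positive allosteric modulation of metabotropic glutamate receptor 5 (Homo sapiens), read by FLIPR, with a stated time of 1 h (on this read-out higher numbers stand for an effect only at larger amounts of compound and lower numbers for an effect already at smaller amounts), compound 2 gives only a limit, > 10000 nM, an assay limit and not a number. Compound 2 thus sits at the limit of > 10000 nM in this assay, at which 1 of the 3 values shown sits, and has no measured value of its own. Among the compounds with values here, compound 1 gives 1500 nM and compound 3 gives 2.5 nM; these two numbers lie far apart, but the compounds differ in more than one place and no single step links them.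

Compound 4 `O=C(C1CCCCC1)N1CCc2nc(C#Cc3ccccc3)sc2C1` is not yet measured; it differs from compound 2 in one place, (cyclohexyl in place of methyl on a carbonyl carbon). Within the data shown here, no measured step covers this change, so the direction is read from compound 3, whose carbonyl carbon also carries a ring and which gives 2.5 nM. A step beyond the scatter toward lower numbers is expected, an at least 160-fold lower number from compound 2 to compound 4 (2.22 log units; beyond the scatter). Compound 4 is estimated at 60 nM, within 6 nM to 600 nM.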

Compound 4, half-maximal effective concentration: 167 nM
Beside the measured number, compound 4's estimate is 2.8-fold (0.44 log units) below it, and the stated range covers the measured number.
By their numbers in this assay, from the lowest: compound 3; then compound 4; then compound 1. At a limit, above all of these: compound 2.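

Cyclohexyl in place of methyl on a carbonyl carbon gives, in this assay, an at least 59-fold lower number from compound 2 to compound 4 (1.77 log units; beyond the scatter) as the first single-place step in the series, so this position affects the read-out strongly. The size of that step has only a lower bound, since compound 2 gives a limit and not a number: the limit of > 10000 nM in this assay, at which 1 of the 4 values shown sits.

On these data alone, whether the ring or simply the larger number of carbons carries the step remains open. So does the outcome with a longer chain such as n-butyl, a smaller ring such as cyclopropyl, or an amine on the cyclohexyl.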